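A few compounds are considered here, and "the series" means these few. Any claim that something is new, unique, unknown or untested is made for them only; others in the source may bear on it.

Measured compounds in an assay on HEK293 cells for displacement of a labelled ligand from NPC1-like intracellular cholesterol transporter 1 (Homo sapiens); a higher number here means a weaker inhibitor, a lower number a stronger inhibitor:
- compound 1 `COC(=O)CCCNC(=O)CN1CN(c2ccccc2)C2(CCN(C(=O)c3ccc(C4CCCCC4)cc3)CC2)C1=O`: 2500 nM
- compound 2 `O=C(CN1CN(c2ccccc2)C2(CCN(C(=O)c3ccc(C4CCCCC4)cc3)CC2)C1=O)N1CCC(CO)CC1`: 1100 nM
- compound 3 `CCc1nn(CC)c(C2CCN(C(=O)CN3CN(c4ccccc4)C4(CCN(C(=O)c5ccc(C6CCCCC6)cc5)CC4)C3=O)CC2)c1C`: "not determined" (no result reported)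

Compound 2 has the lowest of the two numbers available in this assay; its nearest neighbour is compound 1, a step away of a 2.3-fold lower number from compound 1 to compound 2 (0.36 log units; beyond the scatter), and compound 3 contributes no number.

Compound 4 `CS(=O)(=O)NCCNC(=O)CN1CN(c2ccccc2)C2(CCN(C(=O)c3ccc(C4CCCCC4)cc3)CC2)C1=O` is the next member. Relative to compound 2 the change is (2-(methanesulfonamido)ethyl)amino in place of 4-(hydroxymethyl)piperidin-1-yl on a carbonyl carbon. Among the compounds with values here, the only measured step that bears on it is a 2.3-fold lower number from compound 1 to compound 2 (0.36 log units; beyond the scatter), in which the same carbonyl carbon carried an acyclic (3-(methoxycarbonyl)propyl)amino group in compound 1 and the 4-(hydroxymethyl)piperidin-1-yl group in compound 2. Within the data shown here, compound 4 returns to an acyclic amino substituent at that carbonyl, so the expectation is that it sits nearer to compound 1 than to compound 2, a step of a 1.8-fold higher number from compound 2 to compound 4 (0.26 log units; within the scatter) upward in this assay, though with the single comparison available the direction is not firmly anchored. For compound 4 the estimate in this assay is 2000 nM, with a range of 900 nM to 4500 nM.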

Compound 4, half-maximal inhibitory concentration: 2100 nM
Compound 4: the middle estimate sits 1.1-fold (0.02 log units) below what was measured; measured number inside the range.
By their numbers in this assay, from the lowest: compounds 2, 4 and 1 (each within the scatter of the next, the first and the last beyond it).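

In this assay, replacing the 4-(hydroxymethyl)piperidin-1-yl group on this carbonyl carbon with the open (2-(methanesulfonamido)ethyl)amino chain gives a 1.9-fold higher number from compound 2 to compound 4 (0.28 log units; within the scatter), and replacing (methoxycarbonyl)methyl with methanesulfonamido at the chain end gives a 1.2-fold lower number from compound 1 to compound 4 (0.08 log units; within the scatter). Compound 4 therefore cannot be separated from either neighbour, although those two neighbours differ beyond the scatter, so the earlier step cannot be read simply as ring against open chain. No measurement available here explains these results.

Still open, going by these compounds, is whether a plain piperidine without the hydroxymethyl group separates from compound 2. On these data alone, it is also open whether a chain ending in a carboxylic acid or a primary amine moves the number beyond the scatter at this carbonyl carbon.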